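This account rests on a few compounds, and the source may have more. Where it says the series, first, only, none or still open, it means among the compounds named here.

Of the compounds shown here, three of one family have been measured. Compound 1 `O=S(=O)(NCCCNCc1ccccc1Cl)c1cc(C(F)(F)F)cc(C(F)(F)F)c1` gives 10000 nM in a functional assay on HPAC cells (Homo sapiens) for inhibition, read by MTT assay, with a stated time of 72 h; on this read-out lower numbers stand for stronger inhibition of growth and higher numbers for weaker inhibition of growth. Compound 2 `COc1ccc(CNCCCNS(=O)(=O)c2cc(C(F)(F)F)cc(C(F)(F)F)c2)cc1OC` gives 3500 nM in this assay. Compound 3 `O=S(=O)(NCCCNCc1ccc(-c2ccccc2)cc1)c1cc(C(F)(F)F)cc(C(F)(F)F)c1` gives 2700 nM in this assay. Among these three numbers compound 2 holds the second highest; its step to compound 3 lies within the scatter, while a 2.9-fold lower number from compound 1 to compound 2 (0.46 log units; beyond the scatter) stands beyond it.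

Compound 4 `COc1ccc(CNCCCNS(=O)(=O)c2cc(C(F)(F)F)cc(C(F)(F)F)c2)cc1` has not yet been measured. It differs from compound 2 in one place: hydrogen in place of methoxy on an aromatic carbon. Among the measured compounds shown here, no measured pair shows this exact change, so the only guide is how the aryl group on the amine side of the chain has mattered so far: the swap from compound 1 to compound 2 gave a modest step, and compound 3 sits close to compound 2. Removing one methoxy is a smaller change than either of those, so the expected step of a 1.3-fold higher number from compound 2 to compound 4 (0.11 log units; within the scatter) is small, perhaps a slight weakening. Compound 4 is therefore estimated at 4500 nM in this assay, within a range from 2000 nM to 10000 nM.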

Compound 4, concentration for 50% growth inhibition: 3000 nM
The estimate for compound 4 lay 1.5-fold (0.18 log units) above the measured number, within the range that was stated.
By their numbers in this assay, from the lowest: compounds 3, 4 and 2 (each within the scatter of the next); then compound 1.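

In this assay, the methoxy group that sits ortho to a methoxy group can give way to hydrogen with no readable effect, as a 1.2-fold lower number from compound 2 to compound 4 (0.07 log units; within the scatter) shows, so 3,4-dimethoxyphenyl and 4-methoxyphenyl cannot be told apart here. This position also tolerates a much larger swap: with a 1.1-fold higher number from compound 3 to compound 4 (0.05 log units; within the scatter), methoxy and phenyl on the aromatic carbon cannot be told apart either. A single methoxy group is enough to keep the separation from the 2-chlorophenyl compound, with a 3.3-fold lower number from compound 1 to compound 4 (0.52 log units; beyond the scatter), although this step remains modest.

No measurement is available that explains why these groups give such similar numbers. On these data alone, it remains open how an amine or a carboxylic acid on this aromatic ring, or a longer chain in the shared core, would affect growth inhibition.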